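This account rests on a few compounds, and the source may have more. Where it says the series, first, only, none or still open, it means among the compounds named here.

Compound 2 `Clc1cnc(Nc2cn[nH]c2)nc1Nc1ccccc1` sits at the limit of a functional assay on MOLT-4 cells (Homo sapiens) for antiproliferative activity, read by MTT assay, with a stated time of 48 h (on this read-out higher numbers stand for weaker inhibition and lower numbers for stronger inhibition), and in this assay compound 2 gives > 5000 nM which is a limit of the assay rather than a number. Its nearest neighbour, compound 1 `Clc1ccc(Nc2nc(Nc3cn[nH]c3)ncc2Cl)cc1`, carries a chloro group on the six-membered aromatic ring of carbon only, and in this assay compound 1 gives 1370 nM. Going by the values given here, the one change between them, an at least 3.6-fold higher number from compound 1 to compound 2 (0.56 log units; beyond the scatter), shows that losing that chloro weakens inhibition, though how far remains hidden at the limit of > 5000 nM in this assay, at which 1 of the 3 values shown sits. Compound 3 `COc1ccc(Nc2nc(Nc3cn[nH]c3)ncc2Cl)cc1` has a methoxy group where compound 1 has its chloro; for compound 3 the entry in this assay reads "not determined" (no result reported), so no result was reported.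

Compound 4 `Clc1ccccc1Nc1nc(Nc2cn[nH]c2)ncc1Cl` differs from compound 2 by chloro in place of hydrogen on an aromatic carbon. Among the compounds with values here, the only measured step that bears on this is an at least 3.6-fold higher number from compound 1 to compound 2 (0.56 log units; beyond the scatter), in which removing a chloro raised the number beyond the scatter; compound 4 restores a chloro, though ortho to a large group rather than where it sits in compound 1, so the comparison is inexact and the true size is uncertain. Compound 4 is therefore expected to move to a lower number by a modest step, an at least 1.6-fold lower number from compound 2 to compound 4 (0.22 log units; that floor lies within the scatter). Compound 4 is estimated at 3000 nM, within a range from 1000 nM to 8000 nM.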

Compound 4, half-maximal inhibitory concentration: 1260 nM
Compound 4: middle estimate off by 2.4-fold (0.38 log units), on the high side; the measured number falls inside the stated range.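

In this assay, the change from phenyl to 2-chlorophenyl gives an at least 3.9-fold lower number from compound 2 to compound 4 (0.59 log units; beyond the scatter), so the gain in inhibition that goes with a chloro on this ring is not tied to the place it holds in compound 1. The two placements cannot be told apart in this read-out, as 2-chlorophenyl in place of 4-chlorophenyl gives a 1.1-fold lower number from compound 1 to compound 4 (0.04 log units; within the scatter), a step that stays within the scatter and so puts neither compound ahead of the other. The size of the gain from either chloro stays a floor and not a measured step, as compound 2 stands at a limit of the assay and not at a number: the limit of > 5000 nM in this assay, at which 1 of the 4 values shown sits.

The compounds shown leave open whether this gain belongs to chloro itself or would also appear with another group on the same ring, such as a fluoro, a methyl, a trifluoromethyl or an amine. They also leave open whether a second chloro on that ring would add to the first or would give a number no different from those of compound 1 and compound 4.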